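Removing the Ring Methyl from Compound 3

The compounds below may be only part of what the source reports. "The series", "measured", "known", "first", "only" and "open" are said of these compounds alone.

In a functional assay on HEK293 cells for antagonist activity at cysteinyl leukotriene receptor 2 (Homo sapiens), read by fluorescence and calcium flux, with stated times of 30 min and 1 h (a lower number here means a stronger inhibitor, a higher number a weaker inhibitor), compound 3 `Cc1c(CCCC(=O)O)c2cccc(/C=C/c3ccc(OCCCCc4c(F)ccc(F)c4F)cc3)c2n1CC(=O)O` gives 1 nM, the lowest of the three numbers shown. Compound 2 `O=C(O)CCCc1cn(CC(=O)O)c2c(/C=C/c3ccc(OCCCCOc4ccccc4)cc3)cccc12` gives 6 nM, and compound 1 `Cc1c(F)cccc1CCCCOc1ccc(/C=C/c2cccc3c(CCCC(=O)O)cn(CC(=O)O)c23)cc1` gives 14 nM. Within the data shown here, the only measured step between two compounds that differ in one place is a 2.3-fold lower number from compound 1 to compound 2 (0.37 log units; beyond the scatter), and it concerns the chain end, not the five-membered ring. Compound 4 `O=C(O)CCCc1cn(CC(=O)O)c2c(/C=C/c3ccc(OCCCCc4c(F)ccc(F)c4F)cc3)cccc12` differs from compound 3 by hydrogen in place of methyl on an aromatic carbon. Among the measured compounds shown here, compound 1 and compound 2 both carry hydrogen at that place, but neither shares the chain end of compound 3, so no measured step bears directly on this change. The gap between compound 3 and compound 2 may reflect the chain end, the methyl, or both, and the data cannot separate them. A small loss is expected, within or just beyond the scatter, giving a 2.0-fold higher number from compound 3 to compound 4 (0.30 log units; within the scatter). Compound 4 is therefore estimated at 2 nM, with a range from 0.7 nM to 6 nM.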

Compound 4, half-maximal inhibitory concentration: 2.1 nM
Compound 4: the middle estimate sits 1.1-fold (0.02 log units) below what was measured; the range from low to high includes it.
By their numbers in this assay, from the lowest: compound 3; then compound 4; then compound 2; then compound 1.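

In this assay the aromatic carbon next to the ring nitrogen now has a direct reading, since hydrogen in place of methyl gives a 2.1-fold higher number from compound 3 to compound 4 (0.32 log units; beyond the scatter) with the chain end held constant. With hydrogen held at that carbon, the chain end can also be read on its own: 2,3,6-trifluorophenyl in place of phenoxy gives a 2.9-fold lower number from compound 2 to compound 4 (0.46 log units; beyond the scatter) and 2,3,6-trifluorophenyl in place of 3-fluoro-2-methylphenyl gives a 6.7-fold lower number from compound 1 to compound 4 (0.82 log units; beyond the scatter) in the same series. Both places therefore move the number beyond the scatter, but nothing available accounts for either change.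

On these data alone, whether the methyl has a similar effect alongside the phenoxy chain end remains open. Also open, as far as these compounds go, is how an ethyl group, a chlorine atom or a methoxy group would compare on this aromatic carbon.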